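Acetamido to dimethylcarbamoyl on a shared core

The compounds below may be only part of what the source reports. "The series", "measured", "known", "first", "only" and "open" are said of these compounds alone.

Measured compounds:
compound 1 `CCCCN(c1nc2c(CO)cccc2o1)[C@H](C)c1ccc(-c2ccccc2-c2nnn[nH]2)cc1` — 1.6 h
compound 2 `CCCCN(c1nc2c(NC(C)=O)cccc2o1)[C@H](C)c1ccc(-c2ccccc2-c2nnn[nH]2)cc1` — 2.2 h

In an ADME assay on the whole organism (Macaca fascicularis) for metabolic stability, read by LC-MS, using cassette dosing, at a dose of 1 mg/kg by the oral route (a lower number here means that the compound disappears faster, a higher number that the compound lasts longer), compound 1 gives 1.6 h and compound 2 gives 2.2 h. For the measured compounds named here, the only step between them, a 1.4-fold higher number from compound 1 to compound 2 (0.14 log units; within the scatter), falls within the scatter, so compound 2 cannot be told apart from compound 1 on these numbers.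

Compound 3 `CCCCN(c1nc2c(C(=O)N(C)C)cccc2o1)[C@H](C)c1ccc(-c2ccccc2-c2nnn[nH]2)cc1` has not yet been measured. It differs from compound 2 in one place: dimethylcarbamoyl in place of acetamido on an aromatic carbon. Going by the values given here, no measured step exchanges these two groups, and the one step recorded at this place, a 1.4-fold higher number from compound 1 to compound 2 (0.14 log units; within the scatter), stayed within the scatter. The expectation for this assay is therefore a step no larger than the scatter, in no particular direction, so that compound 3 is expected to give 2 h. Compound 3 is estimated to fall between 1 h and 4 h. The expected step from compound 2 is a 1.1-fold lower number from compound 2 to compound 3 (0.04 log units; within the scatter).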

Compound 3, half-life: 3.2 h
For compound 3 the middle estimate is 1.6-fold (0.20 log units) below the measured one, and the stated range covers the measured number.
By their numbers in this assay, from the lowest: compounds 1, 2 and 3 (each within the scatter of the next).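

In this assay, dimethylcarbamoyl on this aromatic carbon gives a 1.5-fold higher number from compound 2 to compound 3 (0.16 log units; within the scatter) and, set against hydroxymethyl, a 2.0-fold higher number from compound 1 to compound 3 (0.30 log units; within the scatter) as the second step. The exchange for acetamido takes the count of hydrogen-bond donors in the group from 1 to 0 and adds a heavy atom, yet the half-life stays within the scatter. Three different groups at this place now give half-lives that cannot be told apart, and this holds for the widest step among them as well. No measured evidence here bears on why these groups cannot be told apart.

On these data alone, whether a carboxylic acid or an amine on this aromatic carbon would give a step beyond the scatter remains open. So does whether dimethylcarbamoyl would behave the same way on a different core.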